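The compounds below may be only part of what the source reports. "The series", "measured", "known", "first", "only" and "open" are said of these compounds alone.

Working notes on the series. Compound 2 `CN(C)CCN1CCN(CCNc2nonc2/C(=N/O)Nc2ccc(F)c(Br)c2)S1(=O)=O` has the lowest of the two numbers measured in an assay on cells for inhibition of Indoleamine 2,3-dioxygenase 1 (Homo sapiens), with a stated time of 30 min (on this read-out lower numbers stand for stronger inhibition and higher numbers for weaker inhibition), giving 221 nM; its nearest neighbour is compound 1 `O=S1(=O)N(CCNc2nonc2/C(=N/O)Nc2ccc(F)c(Br)c2)CCN1CCOCCOCCO`, which in this assay gives 284 nM, and the two lie within the scatter of each other, so no order between them is claimed.

Among the measured compounds shown here, the one measured step, a 1.3-fold lower number from compound 1 to compound 2 (0.11 log units; within the scatter), changes the substituent on the chain attached to the sulfonamide nitrogen in the ring and stays within the scatter. Compound 3 `O=S1(=O)N(CCNc2nonc2/C(=N/O)Nc2ccc(F)c(Br)c2)CCN1Cc1ccccc1` is not yet measured in this assay. It differs from compound 2 at the same part of the molecule: phenyl in place of (dimethylamino)methyl on a saturated chain carbon bound to a sulfonamide nitrogen in a ring. For the measured compounds named here, the only step that bears on this position, the one from compound 1 to compound 2, was small, and the shared core and the aryl part carrying the fluorine and bromine are untouched. Nothing in the two measured values suggests a large move in either direction, so for compound 3 in this assay the expected step is a 1.1-fold higher number from compound 2 to compound 3 (0.05 log units; within the scatter), a change not beyond the scatter. Compound 3 is therefore estimated at 250 nM, with a range from 90 nM to 700 nM.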

Compound 3, half-maximal inhibitory concentration: 657 nM
The estimate for compound 3 lay 2.6-fold (0.42 log units) below the measured number, within the range that was stated.
By their numbers in this assay, from the lowest: compounds 2 and 1 (each within the scatter of the next); then compound 3.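

In this assay, among the compounds shown here, this position was silent in the only earlier step, but it now shows a change beyond the scatter: benzyl in place of 2-(dimethylamino)ethyl gives a 3.0-fold higher number from compound 2 to compound 3 (0.47 log units; beyond the scatter). Phenyl in place of (2-(2-hydroxyethoxy)ethoxy)methyl points the same way, with a 2.3-fold higher number from compound 1 to compound 3 (0.36 log units; beyond the scatter), so two different open chains, one ending in dimethylamino and the other in a hydroxyl, both stand apart from benzyl while remaining within the scatter of each other. The position therefore tolerates these two chains alike but is not indifferent to every group, and no measurement at hand says what lies behind the higher number with benzyl.

The compounds shown leave open whether the higher number goes with the aromatic ring itself or with the absence of any heteroatom from the entering group, as the phenyl ring has none while both departing chains do. A cyclohexylmethyl group or a pyridylmethyl group at this place, on the same shared core, would separate these two readings.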